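A few compounds are considered here, and "the series" means these few. Any claim that something is new, unique, unknown or untested is made for them only; others in the source may bear on it.

Working notes on the series.

Compound 1 `COc1cccc(CNCc2c(C(=O)O)n(Cc3ccc(C)cc3)c3cc(C)ccc23)c1` gives 7310 nM in a functional assay on Bel7402/5-FU cells (Homo sapiens) for antiproliferative activity, read by MTT assay, with a stated time of 72 h; on this read-out higher numbers stand for weaker inhibition and lower numbers for stronger inhibition. Compound 2 `COc1cccc(CNCc2c(C(=O)O)n(Cc3ccccc3)c3cc(C(C)C)ccc23)c1` gives 5920 nM in this assay; the values of compound 1 and compound 2 lie within the scatter of each other, so no order between them can be drawn. Compound 3 `COc1cccc(CNCc2c(C(=O)O)n(Cc3ccc(O)cc3)c3cc(C(C)C)ccc23)c1` is reported in this assay only as a limit, > 50000 nM. Within the data shown here, the one measured step, an at least 8.4-fold higher number from compound 2 to compound 3 (0.92 log units; beyond the scatter), is read against (the limit of > 50000 nM in this assay, at which 1 of the 3 values shown sits).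

Compound 4 `COc1cccc(CNCc2c(C(=O)O)n(Cc3ccc(C)cc3)c3cc(C(C)C)ccc23)c1` is not yet measured. It differs from compound 1 by isopropyl in place of methyl on an aromatic carbon. Among the measured compounds shown here, no measured step concerns this change: the single measured step turns on a hydroxy group on a different ring, and compound 1 and compound 2 differ in two places at once, so their pair of values shows only that a methyl and an isopropyl on the core each sit near the same number. Without a matched step, no shift beyond the scatter is expected in this assay. Compound 4 is therefore estimated at 6500 nM, range 3000 nM to 14000 nM, the expected step being a 1.1-fold lower number from compound 1 to compound 4 (0.05 log units; within the scatter).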

Compound 4, half-maximal inhibitory concentration: 4550 nM
Compound 4: the middle estimate sits 1.4-fold (0.15 log units) above what was measured; the range from low to high includes it.
By their numbers in this assay, from the lowest: compounds 4, 2 and 1 (each within the scatter of the next). At a limit, above all of these: compound 3.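

In this assay, the matched step a 1.6-fold lower number from compound 1 to compound 4 (0.21 log units; within the scatter) shows that isopropyl in place of methyl on an aromatic carbon of the shared core does not move the number beyond the scatter. On the other aromatic ring, methyl in place of hydrogen, a 1.3-fold lower number from compound 2 to compound 4 (0.11 log units; within the scatter), also stays within the scatter, whereas methyl in place of hydroxy, an at least 10-fold lower number from compound 3 to compound 4 (1.04 log units; beyond the scatter), goes beyond it, so among the three groups compared there, only hydroxy stands apart. That last step starts from a limit, not from a measured number: the limit of > 50000 nM in this assay, at which 1 of the 4 values shown sits.

From the compounds shown here alone, whether a tert-butyl group or an amine in place of the isopropyl would leave the number unchanged remains open. Going by these compounds, it is also open whether a methoxy group or a carboxylic acid on the other ring would behave like hydroxy or like methyl.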